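The compounds below may be only part of what the source reports. "The series", "measured", "known", "first", "only" and "open" are said of these compounds alone.

Measured so far:
- compound 1 `c1ccc(/N=N/N2CCN(c3ccccc3)CC2)cc1`: > 100000 nM
- compound 2 `Clc1cccc(/N=N/N2CCCCC2)c1`: > 100000 nM

In an ADME assay on BHK-21 cells (Mesocricetus auratus) for cytotoxicity, read by MTT assay, with a stated time of 96 h (on this read-out lower numbers stand for higher toxicity in this test and higher numbers for lower toxicity in this test), compound 1 gives > 100000 nM, which is a limit of the assay and not a number. Compound 2 gives > 100000 nM, also a limit. Compound 1 therefore has no exact position in the series, and the evidence so far amounts to the limit of > 100000 nM in this assay, at which 2 of the 2 values shown sit.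

Compound 3 `c1ccc(/N=N/N2CCN(c3ncccn3)CC2)cc1` has pyrimidin-2-yl in place of phenyl on an amine nitrogen in a ring of the core of compound 1: pyrimidin-2-yl in place of phenyl on an amine nitrogen in a ring. For the measured compounds named here, no step between measured compounds gauges this change, so no shift beyond the scatter is expected in this assay, in either direction. The expected change is a number no higher from compound 1 to compound 3 (the limit leaves the size open). This expectation rests on compound 1 and its limit of > 100000 nM. The estimated value for compound 3 is 100000 nM, with an expected range of 40000 nM to 200000 nM.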

Compound 3, half-maximal cytotoxic concentration: > 100000 nM
Compound 3 ended at the assay's limit; the forecaster's own chance of this, stated with the estimate: 75%; the middle value lies on the limit itself.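

No new step can be read from compound 1 to compound 3 in this assay, since both compounds stand at a limit and not at a number: the limit of > 100000 nM in this assay, at which 3 of the 3 values shown sit.

The compounds shown leave open how far each lies beyond that limit, and whether pyrimidin-2-yl in place of phenyl changes the read-out at all.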